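Furan-2-yl in place of thiophen-2-yl: expected cytotoxicity

A few compounds are considered here, and "the series" means these few. Any claim that something is new, unique, unknown or untested is made for them only; others in the source may bear on it.

Compound 1 `NC(=O)c1sc2nc(-c3ccccc3)cc(C(F)(F)F)c2c1N`: in an ADME assay on Huh-7 cells (Homo sapiens) for cytotoxicity, read by MTT assay, with a stated time of 72 h (on this read-out lower numbers stand for higher toxicity in this test and higher numbers for lower toxicity in this test), compound 1 sits at the assay limit, > 20000 nM.
Compound 2 `CCOC(=O)c1sc2nc(-c3cccs3)cc(C(F)(F)F)c2c1N`: in this assay compound 2 likewise sits at the assay limit, > 20000 nM.

Both values are limits rather than numbers, so compound 2 cannot be ordered against compound 1 (the limit of > 20000 nM in this assay, at which 2 of the 2 values shown sit). Compound 3 `CCOC(=O)c1sc2nc(-c3ccco3)cc(C(F)(F)F)c2c1N` differs from compound 2 by furan-2-yl in place of thiophen-2-yl on an aromatic carbon. Going by the values given here, no measured step covers this change, so in this assay the expected step is a step that the limit leaves unreadable from compound 2 to compound 3, nothing beyond the scatter. Compound 3 is therefore estimated at 25000 nM, between 10000 nM and 60000 nM.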

Compound 3, half-maximal cytotoxic concentration: > 20000 nM
Compound 3: no number, only a limit (the forecaster's own chance of this, stated with the estimate: 70%); the middle value is on the limit's open side.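

Compound 2 and compound 3 both give limits rather than numbers, so no step between them can be read: the limit of > 20000 nM in this assay, at which 3 of the 3 values shown sit.

The compounds shown leave open how toxic any of them actually is, and whether furan-2-yl in place of thiophen-2-yl changes that at all.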